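Phenyl in Place of Isopropyl on the Ring Nitrogen

This account rests on a few compounds, and the source may have more. Where it says the series, first, only, none or still open, it means among the compounds named here.

Compound 1 `CCc1nn(C)c2c1C(c1cccc(F)c1)=NCC(=O)N2C` gives 10 mg/kg in a functional assay on the whole organism (strain Holtzman) with Rattus norvegicus as the target; a lower number here means that less compound is needed, a higher number that more compound is needed for the effect.
Compound 2 `CCCn1nc(C)c2c1NC(=O)CN=C2c1ccccc1Cl` gives 40 mg/kg in this assay.
Compound 3 `Cc1nn(C(C)C)c2c1C(c1ccccc1Cl)=NCC(=O)N2` gives 20 mg/kg in this assay.

In this assay compound 3 stands second highest of the three numbers. Its nearest neighbour is compound 1 and its furthest is compound 2, and both of those gaps lie within the scatter, so the three compounds cannot be ranked against one another on these figures.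

Compound 4 `Cc1nn(-c2ccccc2)c2c1C(c1ccccc1Cl)=NCC(=O)N2` differs from compound 3 in one place: phenyl in place of isopropyl on an aromatic nitrogen. For the measured compounds named here, the only measured step that touches this place is a 2.0-fold lower number from compound 2 to compound 3 (0.30 log units; within the scatter), and it stayed within the scatter. Going by the values given here, that step exchanged one alkyl chain for another on the aromatic nitrogen; no measured step puts an aromatic ring there, so the data give no direct guide to the size or direction of the present change.

On that basis compound 4 is expected to give about 20 mg/kg in this assay, with a range from 7 mg/kg to 60 mg/kg. Among the compounds with values here, the step this estimate means, no change at the digits printed from compound 3 to compound 4 (within the scatter), is expected to lie within the scatter, the wide range reflecting that the phenyl has no measured precedent at this place.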

Compound 4, minimum effective dose: 20 mg/kg
For compound 4 middle estimate and measured number coincide at the digits printed; the range from low to high includes it.
By their numbers in this assay, from the lowest: compounds 1, 3, 4 and 2 (each within the scatter of the next, the first and the last beyond it).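

On the aromatic nitrogen, a phenyl with 6 heavy atoms and one six-membered aromatic ring of carbon only can take the place of the isopropyl with its 3 heavy atoms, and in this assay this exchange gives no change at the digits printed from compound 3 to compound 4 (within the scatter). The exchange of phenyl for propyl at the same place gives a 2.0-fold lower number from compound 2 to compound 4 (0.30 log units; within the scatter), so with compounds 2, 3 and 4 this position now holds two alkyl groups and an aromatic ring, and the figures do not separate any of the three. These compounds therefore extend what was seen at this nitrogen from an exchange of one alkyl chain for another to an exchange of alkyl for an aromatic ring, but no measurement offers an explanation for the lack of a resolved difference.

Still open, from the compounds shown here alone, is whether this holds for a phenyl that itself carries a further group, such as an amine or a carboxylic acid, or for a longer chain such as hexyl on the same nitrogen. The compounds shown also leave open whether a benzyl group, which sets a methylene between the nitrogen and the ring, would fall within the same narrow spread.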